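From compound 2 to compound 3: one group exchanged

A few compounds are considered here, and "the series" means these few. Any claim that something is new, unique, unknown or untested is made for them only; others in the source may bear on it.

- compound 1 (`Cc1oc(-c2ccccc2Cl)nc1C(=O)N[C@H]1CN(S(=O)(=O)c2ccccc2)C[C@@H]1C(=O)N[C@H]1CCCNC1`): 10000 nM
- compound 2 (`O=C(N[C@H]1CN(S(=O)(=O)c2ccccc2)C[C@@H]1C(=O)N1C[C@H]2CCNC[C@H]21)c1cc(-c2ccccc2Cl)on1`): 265000 nM

In a physicochemical assay for solubility, at pH 7.4 (a higher number here means a more soluble compound, a lower number a less soluble compound), compound 2 stands highest of the two measured compounds at 265000 nM, while compound 1 gives 10000 nM. That gap lies beyond the scatter. Compound 3 (`CC(=O)N1CCC[C@H](NC(=O)[C@H]2CN(S(=O)(=O)c3ccccc3)C[C@@H]2NC(=O)c2cc(-c3ccccc3Cl)on2)C1`) differs from compound 2 on a carbonyl carbon: a group of 10 heavy atoms (7 carbon, 2 nitrogen, 1 oxygen; one six-membered non-aromatic ring with 1 hetero atom) in place of a group of 8 heavy atoms (6 carbon, 2 nitrogen; one four-membered non-aromatic ring with 1 hetero atom, one six-membered non-aromatic ring with 1 hetero atom), on a carbonyl carbon. Among the measured compounds shown here, no measured pair isolates this change, so any expectation is rough. For the measured compounds named here, compound 2 differs from compound 1 in more than one place, and compound 1, at 10000 nM, is the only guide to how low this series can go. A fall beyond the scatter is expected, an 18-fold lower number from compound 2 to compound 3 (1.25 log units; beyond the scatter). The estimate for compound 3 is 15000 nM, with an expected range of 2000 nM to 100000 nM.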

Compound 3, solubility: < 500 nM
Compound 3 ended at the assay's limit (the forecaster's own chance of this, stated with the estimate: 10%); middle value at least 30-fold (1.47 log units) from the limit.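

In this assay, the group on this carbonyl carbon clearly matters: a group of 10 heavy atoms with one six-membered non-aromatic ring, in place of a group of 8 heavy atoms with a four-membered and a six-membered non-aromatic ring, gives an at least 530-fold lower number from compound 2 to compound 3 (2.72 log units; beyond the scatter). The value of compound 3 is a limit of the assay and not a number, so this step gives only a minimum size: the limit of < 500 nM in this assay, at which 1 of the 3 values shown sits.

Which feature of the entering group accounts for the step remains open. So does how a carboxylic acid or a longer chain on this carbonyl carbon would read in this assay.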